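Replacing an amino linker with a methylene in a thienopyrimidine series

The source may report more compounds than this note shows. Statements on the series, on what has been measured and on what is new or still open speak of the compounds shown alone.

Measured so far:
compound 1, `COc1ccc(-c2nc(CNc3cccc(Cl)c3)nc3ccsc23)cn1`: > 50000 nM
compound 2, `COc1ccc(-c2nc(CSc3ccc(C(F)(F)F)cn3)nc3ccsc23)cn1`: > 50000 nM
compound 3, `O=S(=O)(Cc1nc(-c2ccnc(Cl)c2)c2sccc2n1)c1cccc(Cl)c1`: 63000 nM

In an ADME assay on cells (Homo sapiens) for cytotoxicity, read by resazurin assay, with a stated time of 5 days (on this read-out lower numbers stand for higher toxicity in this test and higher numbers for lower toxicity in this test), compound 1 gives > 50000 nM, which is a limit of the assay and not a number. Compound 2 likewise gives > 50000 nM in this assay, again a limit. Within the data shown here, compound 3 is the only one with a number, 63000 nM in this assay. Compound 1 therefore stands at the limit of > 50000 nM in this assay, at which 2 of the 3 values shown sit, with no number of its own.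

Compound 4, `COc1ccc(-c2nc(CCc3cccc(Cl)c3)nc3ccsc23)cn1`, has not yet been measured. It differs from compound 1 by 3-chlorobenzyl in place of (3-chlorophenyl)amino on a saturated chain carbon bound to an aromatic carbon. Among the measured compounds shown here, no step between measured compounds is available, so there is nothing to calibrate a change against. Since compound 1 sits at a limit and compound 3, with a different substituent at the same place, gives a number close to it, no step beyond the usual scatter is expected from this change. The step that the limit leaves unreadable from compound 1 to compound 4 is the estimated outcome of that expectation. Compound 4 is estimated at 60000 nM (range 30000 nM to 120000 nM) in this assay, most likely reported again only as a limit.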

Compound 4, half-maximal cytotoxic concentration: > 50000 nM
Compound 4 was reported as a limit; the forecaster's own chance of this, stated with the estimate: 70%; the middle value lies beyond the limit too.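

In this assay compound 4 gives > 50000 nM, a limit and not a number. Among these compounds, compound 1 also sits at a limit, so no step between compound 1 and compound 4 can be read: the limit of > 50000 nM in this assay, at which 3 of the 4 values shown sit. The compounds shown leave open whether 3-chlorobenzyl in place of (3-chlorophenyl)amino changes the value at all.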